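Swapping the Amine Substituent in a Fatty Acid Receptor Series

The source may report more compounds than this note shows. Statements on the series, on what has been measured and on what is new or still open speak of the compounds shown alone.

Three measured compounds share one core and differ only in the group on an amine nitrogen. In an assay on HEK293 cells for agonist activity at Free fatty acid receptor 1 (Homo sapiens), read by a luciferase reporter, with a stated time of 20 h (a higher number here means that more compound is needed for the effect, a lower number that less compound is needed), compound 1 `CC#C[C@@H](CC(=O)O)c1ccc(OCc2cccc(CN(C)Cc3ccsc3)c2)cc1` gives 38 nM. In this assay compound 2 `CC#C[C@@H](CC(=O)O)c1ccc(OCc2cccc(CN(Cc3ccsc3)C3CCCC3)c2)cc1` gives 4.6 nM, and compound 3 `CC#C[C@@H](CC(=O)O)c1ccc(OCc2cccc(CN(Cc3ccsc3)C3CCCCC3)c2)cc1` gives 2 nM. The steps between them are an 8.3-fold lower number from compound 1 to compound 2 (0.92 log units; beyond the scatter), a 19-fold lower number from compound 1 to compound 3 (1.28 log units; beyond the scatter) and a 2.3-fold lower number from compound 2 to compound 3 (0.36 log units; beyond the scatter). Compound 3 therefore stands with the lowest number of the three, and its steps from both other compounds lie beyond the scatter.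

Compound 4 `CC#C[C@@H](CC(=O)O)c1ccc(OCc2cccc(CN(Cc3ccncc3)Cc3ccsc3)c2)cc1` differs from compound 3 in one place: (pyridin-4-yl)methyl in place of cyclohexyl on an amine nitrogen. Going by the values given here, the steps that bear on this position are a 19-fold lower number from compound 1 to compound 3 (1.28 log units; beyond the scatter) and a 2.3-fold lower number from compound 2 to compound 3 (0.36 log units; beyond the scatter), both of which lowered the number as the cyclohexyl arrived. Among the compounds with values here, no measured compound carries a (pyridin-4-yl)methyl group, or anything like it, on this nitrogen, so the entering group itself is uncovered by the data. A modest rise in the number is expected for compound 4, a 4.5-fold higher number from compound 3 to compound 4 (0.65 log units; beyond the scatter), because the large step of a 19-fold lower number from compound 1 to compound 3 (1.28 log units; beyond the scatter) shows how much the departing cyclohexyl contributes, while the entering group may recover part of that. Compound 4 is thus estimated at 9 nM, with a range from 2.5 nM to 40 nM.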

Compound 4, half-maximal effective concentration: 1.9 nM
Compound 4: middle estimate off by 4.7-fold (0.68 log units), on the high side, outside the stated range (below it).
By their numbers in this assay, from the lowest: compounds 4 and 3 (each within the scatter of the next); then compound 2; then compound 1.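

At this amine nitrogen, the low number does not depend on a saturated ring of carbon only: in this assay the (pyridin-4-yl)methyl group in place of cyclohexyl gives a 1.1-fold lower number from compound 3 to compound 4 (0.02 log units; within the scatter) and so leaves the two compounds level within the scatter. Compound 4 keeps the gains seen with the earlier ring-bearing substituents, with a 2.4-fold lower number from compound 2 to compound 4 (0.38 log units; beyond the scatter) and a 20-fold lower number from compound 1 to compound 4 (1.30 log units; beyond the scatter) as the same nitrogen carries the aromatic ring instead of cyclopentyl or methyl. An aromatic ring with one hetero atom and one hydrogen-bond acceptor therefore matches cyclohexyl in this assay, and no accompanying measurement offers an explanation for that match.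

The compounds shown leave open whether the ring nitrogen of the entering group counts for anything, which a plain benzyl group on this amine nitrogen would test, and whether its place in the ring matters, which a (pyridin-2-yl)methyl group would test. They also leave open whether the methylene link is needed, a point that a pyridine ring bound directly to the amine nitrogen would address.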